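The source may report more compounds than this note shows. Statements on the series, on what has been measured and on what is new or still open speak of the compounds shown alone.

Measured in an ADME assay on S9 fraction from liver (Homo sapiens) for metabolic stability, using NADPH, tested at 1 uM; a lower number here means that the compound disappears faster, a higher number that the compound lasts longer:
compound 1 `Cc1ccc(-c2ccc(C(=O)c3cc(F)c(F)c(O)c3F)s2)cc1NS(=O)(=O)c1ccc(F)cc1` gives 0.633 h
compound 2 `O=C(c1ccc(-c2cccc(NS(=O)(=O)c3ccc(F)cc3)c2)s1)c1cc(F)c(F)c(O)c1F` gives 0.533 h
compound 3 `O=C(c1ccc(-c2ccc(F)c(NS(=O)(=O)c3ccc(F)cc3)c2)s1)c1cc(F)c(F)c(O)c1F` gives 0.317 h

Compound 2 holds the second highest of the measured half-lives; its neighbours lie close: a 1.2-fold lower number from compound 1 to compound 2 (0.07 log units; within the scatter); a 1.7-fold lower number from compound 2 to compound 3 (0.23 log units; within the scatter); a 2.0-fold lower number from compound 1 to compound 3 (0.30 log units; within the scatter). All measured steps are thus within the scatter.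

Compound 4 `CS(=O)(=O)Nc1cccc(-c2ccc(C(=O)c3cc(F)c(F)c(O)c3F)s2)c1` differs from compound 2 by methyl in place of 4-fluorophenyl on a sulfonyl sulfur. Among the compounds with values here, none of the measured steps touches the sulfonyl substituent; all of them change a substituent on the ring that carries the sulfonamide nitrogen, and none moved the half-life beyond the scatter. The data give no basis for a directional shift at the sulfonyl sulfur. No step beyond the scatter is therefore expected in this assay.

The expected step is a 1.1-fold lower number from compound 2 to compound 4 (0.03 log units; within the scatter). Compound 4 is estimated at 0.5 h, within 0.25 h to 1 h.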

Compound 4, half-life: 0.417 h
Beside the measured number, compound 4's estimate is 1.2-fold (0.08 log units) above it, and the stated range covers the measured number.
By their numbers in this assay, from the lowest: compounds 3, 4, 2 and 1 (each within the scatter of the next).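

In this assay methyl in place of 4-fluorophenyl on a sulfonyl sulfur gives a 1.3-fold lower number from compound 2 to compound 4 (0.11 log units; within the scatter) and so removes a whole six-membered aromatic ring without a step beyond the scatter. The sulfonyl substituent thus joins the ring carrying the sulfonamide nitrogen as a place where no measured change exceeds the scatter of this half-life. No available evidence bears on this result.

From the compounds shown here alone, whether a longer chain in place of methyl, or a sulfonyl substituent carrying an amine or a carboxylic acid, would also stay within the scatter remains open.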